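The compounds below may be only part of what the source reports. "The series", "measured", "known", "first", "only" and "open" are said of these compounds alone.

Working notes on the series. All four compounds share the core of compound 1 `C=CC(=O)Nc1cccc(Nc2nc(Cl)nc(Nc3ccc(OCCOC)cc3)n2)c1`, for which a functional assay on Raji cells (Homo sapiens) for antiproliferative activity, read by CCK-8 assay, with a stated time of 24 h (a lower number here means a stronger inhibitor, a higher number a weaker inhibitor), returned "not determined" (no result reported). For the measured compounds named here, compound 2 `C=CC(=O)Nc1cccc(Nc2ncnc(Nc3ccc(C(=O)Nc4ccccn4)cc3)n2)c1` is the only member with a number: in this assay compound 2 gives 15600 nM. Going by the values given here, compound 3 `C=CC(=O)Nc1cccc(Nc2ncnc(Nc3ccc(-c4ccc(Cl)nc4)cc3)n2)c1` likewise has "not determined" (no result reported) in this assay, so it stands on no number of its own, and the single value in the set belongs to compound 2. The step to compound 4 `C=CC(=O)Nc1cccc(Nc2ncnc(Nc3ccc(-c4cccnc4)cc3)n2)c1` is hydrogen in place of chloro on an aromatic carbon. Among the compounds with values here, no measured pair of this kind exists here, so no direction can be read from the data; the step in this assay is expected to stay within the scatter, its size unknown. Within the data shown here, the only anchor is compound 2 with 15600 nM in this assay. Compound 4 is expected in this assay to give about 9000 nM, within a range from 1500 nM to 45000 nM.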

Compound 4, half-maximal inhibitory concentration: 12400 nM
For compound 4 the middle estimate is 1.4-fold (0.14 log units) below the measured one; the range from low to high includes it.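

In this assay the series gains its first readable step, a 1.3-fold lower number from compound 2 to compound 4 (0.10 log units; within the scatter), so these two different groups on the aromatic carbon are not separated by this measurement. The step from chloro to hydrogen itself cannot be read: compound 3 has no number. No evidence bearing on a cause is available. Still open, as far as these compounds go, is whether an amine or a carboxylic acid in place of pyridin-3-yl would give a number beyond the scatter from that of compound 4 in this assay.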